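Swapping dimethylamino for difluoromethoxy on compound 1

A few compounds are considered here, and "the series" means these few. Any claim that something is new, unique, unknown or untested is made for them only; others in the source may bear on it.

Compound 1 `CCN(CC)c1cc2[nH]c(C3CCCCC3)nc2cc1NC(=O)c1ccc(N(C)C)cc1` offers no number to start from: in an ADME assay on Vero cells (Chlorocebus sabaeus) for cytotoxicity, read by resazurin assay, with a stated time of 3 days (a lower number here means a stronger inhibitor, a higher number a weaker inhibitor), compound 1 gives "not determined" (no result reported). Among the measured compounds shown here, the only other reading comes from compound 2 `COc1ccc(C(=O)Nc2cc3nc(C4CCCCC4)[nH]c3cc2N2CCCC2)cc1`, which shares the core. Compound 2 gives > 100 ug/mL, and this is a limit of the assay, not a number.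

Still unmeasured is compound 3 `CCN(CC)c1cc2[nH]c(C3CCCCC3)nc2cc1NC(=O)c1ccc(OC(F)F)cc1`. The change is a single swap, difluoromethoxy in place of dimethylamino on an aromatic carbon, para to a large group. With no value for compound 1, the size of this step in this assay cannot be read from data, so no step beyond the usual scatter is expected. That expectation leans on compound 2, whose only reading is the limit of > 100 ug/mL, so a high number is expected here too. For compound 3 the estimated value is 75 ug/mL, with an expected range of 25 ug/mL to 150 ug/mL.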

Compound 3, half-maximal inhibitory concentration: > 100 ug/mL
Compound 3 ended at the assay's limit; the forecaster's own chance of this, stated with the estimate: 60%; middle value at least 1.3-fold (0.12 log units) away from the limit.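

Among the compounds shown here, no step from compound 1 to compound 3 can be read in this assay. Compound 3 gives > 100 ug/mL, which is a limit of the assay and not a number. The compounds shown leave open what replacing dimethylamino with difluoromethoxy does to this read-out.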